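Adding a Second Trifluoromethyl on Two Thiazole Cores

The source may report more compounds than this note shows. Statements on the series, on what has been measured and on what is new or still open speak of the compounds shown alone.

Measured so far:
compound 1, `Cc1nc(N(C)C(=O)NC(=O)c2c(F)cccc2F)sc1C(=O)N/N=C/c1cccc(C(F)(F)F)c1`, gives 26.8 ug/mL
compound 2, `CNc1nc(C(F)(F)F)c(C(=O)N/N=C/c2cccc(C(F)(F)F)c2)s1`, gives > 100 ug/mL
compound 3, `Cc1nc(N(C)C(=O)NC(=O)c2c(F)cccc2F)sc1C(=O)N/N=C/c1cc(C(F)(F)F)cc(C(F)(F)F)c1`, gives 12.2 ug/mL

All three were tested in a functional assay on HeLa cells (Homo sapiens) for inhibition, read by MTT assay, with a stated time of 72 h; a lower number here means a stronger inhibitor, a higher number a weaker inhibitor. Compound 3 differs from compound 1 by trifluoromethyl in place of hydrogen on an aromatic carbon, and the result is a 2.2-fold lower number from compound 1 to compound 3 (0.34 log units; beyond the scatter). For compound 2 the assay reports only a limit, > 100 ug/mL, and no number (the limit of > 100 ug/mL in this assay, at which 1 of the 3 values shown sits). How the core of compound 2 differs from that of compound 1 is not broken down here.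

Compound 4, `CNc1nc(C(F)(F)F)c(C(=O)N/N=C/c2cc(C(F)(F)F)cc(C(F)(F)F)c2)s1`, has not yet been measured. It differs from compound 2 by trifluoromethyl in place of hydrogen on an aromatic carbon, the same change in the same surroundings as the step from compound 1 to compound 3. The expected step is an at least 1.4-fold lower number from compound 2 to compound 4 (0.15 log units; that floor lies within the scatter), resting on that earlier step, while compound 2 itself sits at the limit. Compound 4 is therefore expected to give about 70 ug/mL, most likely between 30 ug/mL and 160 ug/mL, with a fair chance that only a limit is reported again.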

Compound 4, half-maximal inhibitory concentration: > 100 ug/mL
Compound 4: only a limit was reported; the forecaster's own chance of this, stated with the estimate: 55%; middle value at least 1.4-fold (0.15 log units) from the limit.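

Compound 2 and compound 4 both report only a limit, so the step between them cannot be read: the limit of > 100 ug/mL in this assay, at which 2 of the 4 values shown sit.

From the compounds shown here alone, whether the added trifluoromethyl changes inhibition at all on the core of compound 2 remains open.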